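Acid in place of alcohol on the chain of compound 3

A few compounds are considered here, and "the series" means these few. Any claim that something is new, unique, unknown or untested is made for them only; others in the source may bear on it.

For the measured compounds named here, compound 3 `OCCCc1nc(Nc2ccc(C(F)(F)F)cc2)c2ccc(-c3ncccc3C(F)(F)F)cc2n1` stands second highest of the three numbers so far in a functional assay for antagonist activity at transient receptor potential cation channel subfamily V member 1 (Homo sapiens) (on this read-out lower numbers stand for stronger inhibition and higher numbers for weaker inhibition), where compound 3 gives 25 nM. Compound 1 `CCOCc1nc(Nc2ccc(C(F)(F)F)cc2)c2ccc(-c3ncccc3C(F)(F)F)cc2n1` gives 0.9 nM and compound 2 `O=C(O)COCc1nc(Nc2ccc(C(F)(F)F)cc2)c2ccc(-c3ncccc3C(F)(F)F)cc2n1` gives 81 nM; the steps of a 90-fold higher number from compound 1 to compound 2 (1.95 log units; beyond the scatter) and a 28-fold higher number from compound 1 to compound 3 (1.44 log units; beyond the scatter) were both large, and a 3.2-fold lower number from compound 2 to compound 3 (0.51 log units; beyond the scatter) was modest. Compound 4 `O=C(O)CCc1nc(Nc2ccc(C(F)(F)F)cc2)c2ccc(-c3ncccc3C(F)(F)F)cc2n1` differs from compound 3 by carboxy in place of hydroxymethyl on a saturated chain carbon, two bonds along the chain from an aromatic carbon. The step from compound 2 to compound 3 is the one that bears on this, since there a carboxy-bearing chain was exchanged for a hydroxy-bearing one and the number fell. Reversing that sense, compound 4 is expected to give a modestly higher number, about a 2.8-fold higher number from compound 3 to compound 4 (0.45 log units; beyond the scatter). Compound 4 is therefore estimated at 70 nM, within 25 nM to 200 nM.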

Compound 4, half-maximal inhibitory concentration in the transient receptor potential cation channel subfamily V member 1 assay: 1630 nM
Beside the measured number, compound 4's estimate is 23-fold (1.37 log units) below it; the whole stated range lies below it.
By their numbers in the transient receptor potential cation channel subfamily V member 1 assay, from the lowest: compound 1; then compound 3; then compound 2; then compound 4.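

In the transient receptor potential cation channel subfamily V member 1 assay a carboxy group on this chain proves far more damaging than the earlier acid indicated: a 65-fold higher number from compound 3 to compound 4 (1.81 log units; beyond the scatter), and a 20-fold higher number from compound 2 to compound 4 (1.30 log units; beyond the scatter), so the outcome for an acid depends on the chain carrying it. Measured against the ethoxy chain, the loss reaches a 1800-fold higher number from compound 1 to compound 4 (3.26 log units; beyond the scatter). The same change has a large opposite gain in a physicochemical assay for solubility, at pH 7.4; a lower number here means a less soluble compound, a higher number a more soluble compound: the measured solubility of compound 3, 0.06 ug/mL, and of compound 4, 125 ug/mL, a 2100-fold higher number (3.32 log units; beyond the scatter) In the physicochemical assay compound 3 gives 0.06 ug/mL and compound 4 gives 125 ug/mL.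

Open, going by these compounds, is whether an amine at the chain end, or a carboxylic acid on a longer chain, would keep that gain without the loss of inhibition.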